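Aryl ether variation on a shared bromo-coumarin-free core

The source may report more compounds than this note shows. Statements on the series, on what has been measured and on what is new or still open speak of the compounds shown alone.

Measured so far:
- compound 1 `O=c1cc(-n2cc(COc3ccnc4ccc(Br)cc34)nn2)c2cc(Br)ccc2o1`, 13300 nM
- compound 2 `COC(=O)c1ccccc1OCc1cn(-c2cc(=O)oc3ccc(Br)cc23)nn1`, 5250 nM
- compound 3 `O=c1cc(-n2cc(COc3ccccc3O)nn2)c2cc(Br)ccc2o1`, 7940 nM

In a functional assay on A549 cells (Homo sapiens) for antiproliferative activity, read by MTT assay, with a stated time of 48 h (a higher number here means a weaker inhibitor, a lower number a stronger inhibitor), compound 3 gives the second highest of the three numbers. Its nearest neighbour is compound 2, and a 1.5-fold higher number from compound 2 to compound 3 (0.18 log units; within the scatter); compound 1 sits furthest away, yet all three values lie within the scatter of one another, so no ordering among them can be claimed.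

Compound 4 `O=c1cc(-n2cc(COc3ccc(F)cc3)nn2)c2cc(Br)ccc2o1` is not yet measured. It differs from compound 3 by 4-fluorophenyl in place of 2-hydroxyphenyl on an oxygen on a saturated carbon. Going by the values given here, the only measured step that bears on this position is the exchange of the substituent on the same aryl ring, where a 1.5-fold higher number from compound 2 to compound 3 (0.18 log units; within the scatter); the wider change to compound 1 likewise leaves its value within the scatter of compound 3. On that basis no step beyond the scatter is expected in this assay for the exchange of the aryl group.

Compound 4 is therefore estimated at 7900 nM in this assay, with a range of 3000 nM to 21000 nM, which corresponds to a 1.0-fold lower number from compound 3 to compound 4 (0.00 log units; within the scatter) as the expected step.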

Compound 4, half-maximal inhibitory concentration: 850 nM
The estimate for compound 4 lay 9.3-fold (0.97 log units) above the measured number; measured number outside the range, below it.
By their numbers in this assay, from the lowest: compound 4; then compounds 2, 3 and 1 (each within the scatter of the next, the first and the last beyond it).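

In this assay, the aryl group on the ether oxygen proves to be a position that can move the number: 4-fluorophenyl in place of 2-hydroxyphenyl gives a 9.3-fold lower number from compound 3 to compound 4 (0.97 log units; beyond the scatter). The earlier exchange on this ring, a 1.5-fold higher number from compound 2 to compound 3 (0.18 log units; within the scatter), gave no sign of this, so a step within the scatter there does not carry over to every aryl change at this place. No measurement shown here accounts for the size of the new step.

This one step removes the hydroxy group, brings in fluorine and changes the substituent's place on the ring all at once, so the compounds shown cannot assign the step to any one of these. A plain phenyl group, or a chlorine or an amine on the same ring, would bear on whether fluorine itself matters or the loss of hydroxy is enough.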